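The compounds below may be only part of what the source reports. "The series", "measured", "known", "first", "only" and "open" are said of these compounds alone.

In an ADME assay on J774 cells (Mus musculus) for cytotoxicity, read by MTT assay, with a stated time of 48 h, tested at 150 ug/mL (on this read-out lower numbers stand for a stronger effect and higher numbers for a weaker effect at the one concentration tested), compound 1 `O=C(N/N=C/c1ccccc1)c1cnccn1` gives 100%, while compound 2 `O=C(N/N=C/c1ccccc1Cl)c1cnccn1` gives 69%, the lowest of the two numbers; the step of a number 31 percentage points lower from compound 1 to compound 2 (beyond the scatter) came with chloro in place of hydrogen on an aromatic carbon. Compound 3 `O=C(N/N=C/c1ccccc1F)c1cnccn1` differs from compound 2 by fluoro in place of chloro on an aromatic carbon. That one measured step bears only loosely here, since it shows what a chloro group added, not how fluoro compares with chloro. For compound 3 the expected step of a number 16 percentage points higher from compound 2 to compound 3 (beyond the scatter) is a moderate rise back toward compound 1, partly undoing that drop. Compound 3 is estimated at 85%, with a range from 65% to 100%.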

Compound 3, a percentage reported as activity, at one concentration (the size of the read-out at that concentration, not a potency): 81%
The estimate for compound 3 lay 4 percentage points above the measured number, within the range that was stated.
By their numbers in this assay, from the lowest: compound 2; then compound 3; then compound 1.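

Swapping one halogen for another at this place on the ring changes the result: in this assay there is a number 12 percentage points higher from compound 2 to compound 3 (beyond the scatter) for fluoro in place of chloro. Fluoro still counts against hydrogen, with a number 19 percentage points lower from compound 1 to compound 3 (beyond the scatter) on the shared core, so both halogens lower the number, chloro by more. Nothing measured here explains why the two halogens differ.

The compounds shown leave open whether a non-halogen group at this place, such as an amine or a methoxy group, would lower the number too. They also leave open where bromo would fall relative to chloro and fluoro.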